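A few compounds are considered here, and "the series" means these few. Any claim that something is new, unique, unknown or untested is made for them only; others in the source may bear on it.

Compound 1 `COc1cc(-c2nn(-c3cccc(NC(=O)Nc4ccc(Cl)c(Cl)c4)c3)cc2-c2ccncc2)ccc1Cl` is the reference point of this set. In a functional assay on OVCAR-3 cells (Homo sapiens) for inhibition, read by sulforhodamine B assay, with a stated time of 48 h (a lower number here means a stronger inhibitor of growth, a higher number a weaker inhibitor of growth), compound 1 gives 2270 nM, the second highest of the three numbers recorded so far. Within the data shown here, its nearest neighbour is compound 2 `O=C(Nc1cccc(-n2cc(-c3ccncc3)c(-c3ccc(Cl)c(O)c3)n2)c1)Nc1ccc(Cl)c(Cl)c1`, which in this assay gives 3150 nM; the only single-point step measured, a 1.4-fold higher number from compound 1 to compound 2 (0.14 log units; within the scatter), stays within the scatter. Compound 3 `O=C(Nc1cccc(-n2cc(-c3ccncc3)c(-c3ccc(Cl)c(O)c3)n2)c1)Nc1cc(C(F)(F)F)cc(C(F)(F)F)c1` gives 1200 nM in this assay, and compounds 1 and 3 also sit within the scatter of each other.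

Compound 4 `COc1cc(-c2nn(-c3cccc(NC(=O)c4ccccc4)c3)cc2-c2ccncc2)ccc1Cl` differs from compound 1 in one place: phenyl in place of (3,4-dichlorophenyl)amino on a carbonyl carbon. Among the measured compounds shown here, no measured step touches this part of the molecule, so the single step available, a 1.4-fold higher number from compound 1 to compound 2 (0.14 log units; within the scatter), bears on it only indirectly, as a sign that the set so far tolerates small edits without moving beyond the scatter. Compounds 2 and 3 differ at the aryl attached to the urea and not in the urea itself, so their two values give no direct guide either. For lack of precedent, compound 4 is expected to give a somewhat higher number than compound 1, a step of about a 1.8-fold higher number from compound 1 to compound 4 (0.25 log units; within the scatter), with wide uncertainty. The estimate for compound 4 in this assay is therefore 4000 nM, expected to fall between 1500 nM and 12000 nM.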

Compound 4, concentration for total growth inhibition: 10900 nM
Compound 4: middle estimate off by 2.7-fold (0.44 log units), on the low side; the range from low to high includes it.
By their numbers in this assay, from the lowest: compounds 3, 1 and 2 (each within the scatter of the next, the first and the last beyond it); then compound 4.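

Read at the carbonyl carbon, phenyl in place of (3,4-dichlorophenyl)amino gives the first single-place step in the series that lies beyond the scatter in this assay (a 4.8-fold higher number from compound 1 to compound 4 (0.68 log units; beyond the scatter)), whereas the one earlier step, at the oxygen on an aromatic ring, stays within it (a 1.4-fold higher number from compound 1 to compound 2 (0.14 log units; within the scatter)). This change removes the amino nitrogen with its hydrogen-bond donor and both chlorine atoms in one edit, and the step cannot be divided among them. No measurement at hand accounts for the step.

A phenylamino group or a 3,4-dichlorophenyl group on the same carbonyl carbon would separate the amino nitrogen from the chlorine atoms. From the compounds shown here alone, whether a benzamido compound carrying hydroxyl in place of the methoxy group follows the same step also remains open.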